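Hydroxy removal on the five-membered ring, phenylsulfonyl series

The compounds below may be only part of what the source reports. "The series", "measured", "known", "first", "only" and "open" are said of these compounds alone.

Measured so far:
compound 1 `CC(=O)c1ccc(NC(=O)C2CC(O)CN2S(=O)(=O)c2ccc([N+](=O)[O-])cc2)cc1` gives 60.1%
compound 2 `CC(=O)c1ccc(NC(=O)C2CCCN2S(=O)(=O)c2ccc([N+](=O)[O-])cc2)cc1` gives 25.3%
compound 3 `CC(=O)c1ccc(NC(=O)C2CC(O)CN2S(=O)(=O)c2ccccc2)cc1` gives 54.5%

All three numbers come from a functional assay for inhibition, read by spectrophotometry, with a stated time of 20 min, tested at 4 mg/mL; on this read-out higher numbers stand for a stronger effect at the one concentration tested and lower numbers for a weaker effect. Compound 3 stands second highest of the three. Its nearest neighbour is compound 1, and the gap a number 5.6 percentage points lower from compound 1 to compound 3 (within the scatter) lies within the scatter, so the two cannot be ordered. Compound 2 is the furthest away: compound 3 gives 54.5% where compound 2 gives 25.3%, a gap beyond the scatter.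

The next compound is compound 4 `CC(=O)c1ccc(NC(=O)C2CCCN2S(=O)(=O)c2ccccc2)cc1`. Relative to compound 3 the change is hydrogen in place of hydroxy on a saturated ring carbon

Among the measured compounds shown here, one measured step bears on this directly: the same exchange of hydroxy for hydrogen on the saturated ring carbon, made within the nitro-bearing pair, gave a number 34.8 percentage points lower from compound 1 to compound 2 (beyond the scatter). The nitro group itself made little difference, as a number 5.6 percentage points lower from compound 1 to compound 3 (within the scatter) shows, so the pair without nitro is expected to behave like the pair with it. A downward step of comparable size is therefore expected, a number 32.5 percentage points lower from compound 3 to compound 4 (beyond the scatter), clearly beyond the scatter.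

For compound 4 in this assay the estimate is 22%, with a range of 8% to 38%.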

Compound 4, a percentage reported as inhibition, at one concentration (the size of the read-out at that concentration, not a potency): 33.4%
Compound 4: middle estimate off by 11.4 percentage points, on the low side, and the stated range covers the measured number.
By their numbers in this assay, from the lowest: compounds 2 and 4 (each within the scatter of the next); then compounds 3 and 1 (each within the scatter of the next).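

The loss on replacing hydroxy with hydrogen at this saturated ring carbon is not confined to the nitro-bearing pair: in this assay the step without nitro is a number 21.1 percentage points lower from compound 3 to compound 4 (beyond the scatter). The two hydroxy steps on the two cores cannot be told apart in size, so a single loss of comparable size fits both: the same change on two cores in this assay, a number 34.8 percentage points lower (beyond the scatter) from compound 1 to compound 2 and a number 21.1 percentage points lower (beyond the scatter) from compound 3 to compound 4, 13.7 percentage points apart, within the scatter of two such steps

The exchange of nitro for hydrogen on the aromatic carbon can now also be read without the hydroxy, as a number 8.1 percentage points higher from compound 2 to compound 4 (within the scatter), and it stays within the scatter with or without that group: the same change on two cores in this assay, a number 5.6 percentage points lower (within the scatter) from compound 1 to compound 3 and a number 8.1 percentage points higher (within the scatter) from compound 2 to compound 4, 13.7 percentage points apart, within the scatter of two such steps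

On these data alone, whether the hydroxy can be replaced at this ring carbon by a methoxy, an amine or a fluorine while the read-out is held remains open, and so does the effect of an amine or a carboxylic acid in place of nitro on the aromatic carbon. All four numbers come from one concentration in this assay, so they speak only of a stronger or weaker effect at that concentration.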